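Swapping the Aryl Group on the Carbonyl Carbon

The source may report more compounds than this note shows. Statements on the series, on what has been measured and on what is new or still open speak of the compounds shown alone.

Measured compounds:
compound 1, `COc1cc(-c2cc(/C=C/C(=O)c3ccc(N)cc3)[nH]n2)cc(OC)c1OC`, in a functional assay on SF-539 cells (Homo sapiens) for inhibition, read by sulforhodamine B assay, with a stated time of 48 h (a higher number here means a weaker inhibitor of growth, a lower number a stronger inhibitor of growth), compound 1 gives 1300 nM
compound 2, `COc1ccc(C(=O)/C=C/c2cc(-c3cc(OC)c(OC)c(OC)c3)n[nH]2)cc1OC`, in this assay compound 2 gives 1270 nM
compound 3, `COc1ccc(C(=O)/C=C/c2cc(-c3cc(OC)c(OC)c(OC)c3)n[nH]2)cc1`, in this assay compound 3 gives 1620 nM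

Compound 3 carries the highest of the three numbers, but its neighbours sit close: a 1.2-fold higher number from compound 1 to compound 3 (0.10 log units; within the scatter) and a 1.3-fold higher number from compound 2 to compound 3 (0.11 log units; within the scatter), both within the scatter, so the three compounds cannot be ordered on these data.

Compound 4 is `COc1cc(-c2cc(/C=C/C(=O)c3ccc(F)c(F)c3)[nH]n2)cc(OC)c1OC`. It differs from compound 3 by 3,4-difluorophenyl in place of 4-methoxyphenyl on a carbonyl carbon. Among the compounds with values here, every measured step so far touches the same aryl group on the carbonyl carbon: a 1.0-fold lower number from compound 1 to compound 2 (0.01 log units; within the scatter), a 1.2-fold higher number from compound 1 to compound 3 (0.10 log units; within the scatter) and a 1.3-fold higher number from compound 2 to compound 3 (0.11 log units; within the scatter), none of them beyond the scatter. Three exchanges of that aryl group therefore left this assay unmoved, and nothing in the data points to the 3,4-difluorophenyl behaving otherwise. The expected step is a 1.0-fold lower number from compound 3 to compound 4 (0.01 log units; within the scatter), that is, no step beyond the scatter. Compound 4 is accordingly estimated at 1600 nM, with a range from 700 nM to 3600 nM.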

Compound 4, concentration for 50% growth inhibition: 3760 nM
Compound 4: the middle estimate sits 2.4-fold (0.37 log units) below what was measured; the measured number lies above the stated range.
By their numbers in this assay, from the lowest: compounds 2, 1 and 3 (each within the scatter of the next); then compound 4.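

This aryl group on the carbonyl carbon is not as indifferent in this assay as the earlier exchanges suggested. With 3,4-difluorophenyl, the number rises beyond the scatter against each of the other compounds, though only modestly (a 2.3-fold higher number from compound 3 to compound 4 (0.37 log units; beyond the scatter); a 3.0-fold higher number from compound 2 to compound 4 (0.47 log units; beyond the scatter); a 2.9-fold higher number from compound 1 to compound 4 (0.46 log units; beyond the scatter)), so compound 4 is a weaker inhibitor of growth than compound 1, compound 2 or compound 3, which stay within the scatter of one another. No evidence is at hand that accounts for this shift.

The compounds shown leave open whether a single fluorine, as in 4-fluorophenyl, would give the same step or whether both fluorines are needed for it. They also leave open how chlorine in place of the fluorines, or a carboxylic acid on that ring, would read.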